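A few compounds are considered here, and "the series" means these few. Any claim that something is new, unique, unknown or untested is made for them only; others in the source may bear on it.

Two amide-linked compounds built on a shared core have been measured in an assay on isolated protein for inhibition of Rho-associated protein kinase 2 (Homo sapiens), read by scintillation counting, radiometric assay and 33P incorporation, with a stated time of 40 min, in the presence of a further agent that is not named here; on this read-out higher numbers stand for weaker inhibition and lower numbers for stronger inhibition. Compound 1 `Cc1cc(C(=O)Nc2cccc(NC(=O)COc3ccc4c(=O)ccoc4c3)c2)no1` gives 5 nM in this assay. Compound 2 `CN(C)c1ccc(C(=O)Nc2cc(F)cc(NC(=O)COc3ccc4c(=O)ccoc4c3)c2)cc1`, which carries a fluoro group on its central ring and a dimethylamino-bearing aryl amide, gives 22 nM in this assay; this is the higher of the two numbers, and the gap to compound 1 lies beyond the usual scatter.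

Compound 3 `CN(C)c1ccc(C(=O)Nc2cc(NC(=O)COc3ccc4c(=O)ccoc4c3)cc(C(F)(F)F)c2)cc1` has not yet been measured. It differs from compound 2 by trifluoromethyl in place of fluoro on an aromatic carbon; the place is an aromatic carbon of a six-membered aromatic ring of carbon only, meta to two large groups. Among the compounds with values here, with no measured pair of this kind to lean on, the expected step from compound 2 to compound 3 is a 1.6-fold higher number from compound 2 to compound 3 (0.20 log units; within the scatter), small and not clearly beyond the scatter. Compound 3 is therefore estimated at 35 nM in this assay, with a likely range from 10 nM to 120 nM.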

Compound 3, half-maximal inhibitory concentration: > 10000 nM
Compound 3: no number, only a limit (the forecaster's own chance of this, stated with the estimate: 3%); middle value at least 280-fold (2.45 log units) away from the limit.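

Replacing fluoro with trifluoromethyl on this aromatic carbon, meta to two large groups, gives an at least 450-fold higher number from compound 2 to compound 3 (2.65 log units; beyond the scatter) in this assay. Compound 3 therefore yields only a limit of the assay, not a number: the limit of > 10000 nM in this assay, at which 1 of the 3 values shown sits. The earlier compounds shown here gave no sign of how much this place could matter, whereas this single pair shows that one change here can cost nearly all measurable inhibition, so this place does not accept every group.

As far as these compounds go, what remains open is whether the loss is particular to trifluoromethyl or extends to other groups larger than fluoro, such as chloro, methyl or methoxy, which would show how sharply inhibition falls away at this place. The compounds shown also cannot say why the loss occurs, since one pair gives the size of the step but not its cause.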